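Replacing the Amino Group of Compound 2

This account rests on a few compounds, and the source may have more. Where it says the series, first, only, none or still open, it means among the compounds named here.

For the measured compounds named here, only two compounds have been measured so far in a functional assay on HepG2 cells (Homo sapiens) for antiproliferative activity, read by MTT assay, with a stated time of 48 h; on this read-out lower numbers stand for stronger inhibition and higher numbers for weaker inhibition. Compound 1 `Cc1ccc(-c2nc3ccc(Cl)cc3c(=S)[nH]2)cc1` gives 7.01 ug/mL. Compound 2 `Cc1ccc(-c2nc(N)c3cc(Cl)ccc3n2)cc1` gives 14.5 ug/mL. Compound 2 therefore has the higher number of the pair, which makes it the weaker inhibitor of the two, and the gap lies beyond the usual scatter of repeated measurements. Compound 3 `Cc1ccc(-c2nc(SCC#N)c3cc(Cl)ccc3n2)cc1` keeps the core of compound 2 but carries (cyanomethyl)sulfanyl in place of amino on an aromatic carbon. Going by the values given here, no two measured compounds differ in just one place, so no earlier step can guide the estimate. The expected change is a 1.5-fold lower number from compound 2 to compound 3 (0.16 log units; within the scatter), a small move toward stronger inhibition that stays within the scatter. For compound 3 the estimated value is 10 ug/mL, with an expected range from 4 ug/mL to 25 ug/mL.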

Compound 3, half-maximal inhibitory concentration: 4.37 ug/mL
Compound 3: the middle estimate sits 2.3-fold (0.36 log units) above what was measured, and the stated range covers the measured number.
By their numbers in this assay, from the lowest: compounds 3 and 1 (each within the scatter of the next); then compound 2.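

In this assay, for the compounds shown here, swapping amino for (cyanomethyl)sulfanyl gives a 3.3-fold lower number from compound 2 to compound 3 (0.52 log units; beyond the scatter), the first change that can be read at a single place. This shows that amino is not required on this aromatic carbon next to the ring nitrogen: a larger group with no hydrogen-bond donor gives a lower number, although this single step changes size, donor count and atom types together. Nothing measured here explains the gain.

The compounds shown leave open which part of the new group matters: the sulfur, the short chain or the nitrile. A plain methylsulfanyl group, or a longer chain on the sulfur ending in a carboxylic acid, would help separate these parts.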